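Shortening the ester chain on a nitro-dihydropyridine

The compounds below may be only part of what the source reports. "The series", "measured", "known", "first", "only" and "open" are said of these compounds alone.

Measured compounds:
compound 1 `CO/C(O)=C1\C(C)=NC(C)=C([N+](=O)[O-])C1c1ccncc1` 48500 nM
compound 2 `CC1=NC(C)=C([N+](=O)[O-])C(c2cccnc2)/C1=C(\O)OC(C)C` 28500 nM
compound 3 `CC1=NC(C)=C([N+](=O)[O-])C(c2ccncc2)/C1=C(\O)OCC(C)C` 8510 nM

In a functional assay (cardiac atrium) for agonist activity, with Cavia porcellus as the target (a lower number here means that less compound is needed, a higher number that more compound is needed for the effect), compound 3 gives the lowest number of the three, and its gaps to compound 2 and compound 1 lie beyond the scatter. Compound 4 `CC1=NC(C)=C([N+](=O)[O-])C(c2ccncc2)/C1=C(\O)OC(C)C` differs from compound 3 only in the ester: isopropyl in place of isobutyl on an oxygen on an unsaturated carbon. Within the data shown here, the one step that bears on this ester chain is a 5.7-fold lower number from compound 1 to compound 3 (0.76 log units; beyond the scatter), where lengthening the chain lowered the number. Taking one carbon away again should therefore move the number back up modestly, and compound 4 is expected to show a 1.8-fold higher number from compound 3 to compound 4 (0.25 log units; within the scatter) in this assay. The estimate for compound 4 is 15000 nM, with a range from 6000 nM to 40000 nM.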

Compound 4, half-maximal effective concentration: 8050 nM
Beside the measured number, compound 4's estimate is 1.9-fold (0.27 log units) above it; the range from low to high includes it.
By their numbers in this assay, from the lowest: compounds 4 and 3 (each within the scatter of the next); then compounds 2 and 1 (each within the scatter of the next).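

In this assay, isopropyl and isobutyl on this oxygen cannot be told apart (a 1.1-fold lower number from compound 3 to compound 4 (0.02 log units; within the scatter)), so the gain over the methyl group is not confined to the longer chain (a 6.0-fold lower number from compound 1 to compound 4 (0.78 log units; beyond the scatter)). With the isopropyl ester held fixed, pyridin-4-yl in place of pyridin-3-yl also lowers the number (a 3.5-fold lower number from compound 2 to compound 4 (0.55 log units; beyond the scatter)). Nothing measured here explains these steps. From the compounds shown here alone, whether a straight propyl chain, a cyclopropyl group or a chain ending in an amine would keep the number this low remains open, as does the effect of a plain phenyl ring in place of pyridin-4-yl.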